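The compounds below may be only part of what the source reports. "The series", "measured", "known", "first", "only" and "open" are said of these compounds alone.

Three esters on the shared core have been tested so far in a functional assay on cells (Platelet, Homo sapiens) for inhibition (a higher number here means a weaker inhibitor, a lower number a stronger inhibitor), and none gives a number. Compound 1 (`CCOC(=O)c1ccc(-c2nn(Cc3cccc(Cl)c3)c3ccccc23)cc1`) gives > 10000 nM as a limit of the assay. Compound 2 (`CCOC(=O)c1cccc(-c2nn(Cc3ccccc3)c3ccccc23)c1`) gives > 10000 nM as a limit as well. Compound 3 (`CCCOC(=O)c1ccc(-c2nn(Cc3ccccc3)c3ccccc23)cc1`) gives > 10000 nM as a limit too, so it has no number of its own. Among the compounds with values here, the series therefore offers only the limit of > 10000 nM in this assay, at which 3 of the 3 values shown sit, and no measured step.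

Compound 4 (`CC(C)NC(=O)c1ccc(-c2nn(Cc3ccccc3)c3ccccc23)cc1`) carries isopropylamino in place of propoxy on a carbonyl carbon and so turns propoxycarbonyl into isopropylcarbamoyl. With compound 3 at > 10000 nM as a limit, the data give no size or direction for this exchange, and little movement is expected. The expected step is a number no higher from compound 3 to compound 4 (the limit leaves the size open) in size, with no firm direction, and a further limit remains the likeliest report. Compound 4 is estimated at 10000 nM with an expected range from 3000 nM to 30000 nM on this reading.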

Compound 4, half-maximal inhibitory concentration: > 10000 nM
Compound 4: no number, only a limit (the forecaster's own chance of this, stated with the estimate: 65%); the middle value sits exactly at the limit.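

Compound 3 and compound 4 both stand only as limits in this assay, so no step can be read for isopropylamino in place of propoxy on a carbonyl carbon: the limit of > 10000 nM in this assay, at which 4 of the 4 values shown sit.

The compounds shown leave open how propoxycarbonyl and isopropylcarbamoyl compare, and whether any compound in the series gives a number in this assay.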